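Extending the Amide Substituent of Compound 2

This account rests on a few compounds, and the source may have more. Where it says the series, first, only, none or still open, it means among the compounds named here.

Measured compounds:
compound 1 `CC(C)(C)c1ccc(C(=O)N2CCC3(CC2)C(=O)N(CC(=O)N2CCC(CCO)CC2)CN3c2ccccc2)cc1` gives 2600 nM
compound 2 `CC(C)(C)c1ccc(C(=O)N2CCC3(CC2)C(=O)N(CC(=O)NCN)CN3c2ccccc2)cc1` gives 26500 nM

Among the measured compounds shown here, compound 2 holds the higher of the two numbers so far. In an assay on HEK293 cells for displacement of a labelled ligand from NPC1-like intracellular cholesterol transporter 1 (Homo sapiens) (a lower number here means a stronger inhibitor, a higher number a weaker inhibitor), compound 2 gives 26500 nM, while compound 1 gives 2600 nM. For the measured compounds named here, the only step between measured compounds is a 10-fold higher number from compound 1 to compound 2 (1.01 log units; beyond the scatter), which shows that the small (aminomethyl)amino terminus is much less favourable than the larger 4-(2-hydroxyethyl)piperidin-1-yl group on the same carbonyl carbon.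

Compound 3 `CC(C)(C)c1ccc(C(=O)N2CCC3(CC2)C(=O)N(CC(=O)NCCCCCNS(C)(=O)=O)CN3c2ccccc2)cc1` differs from compound 2 by 4-(methanesulfonamido)butyl in place of amino on a saturated chain carbon bound to an amide-type nitrogen. This change again replaces the small terminus of compound 2 with a considerably larger group, which is the direction that, from compound 2 back to compound 1, was associated with a large gain. Going by the values given here, only that single step bears on the question, and the new group is not the same as the one in compound 1, so the expectation is uncertain. Compound 3 is therefore expected to return to a lower number than compound 2, by roughly a 6.6-fold lower number from compound 2 to compound 3 (0.82 log units; beyond the scatter), placing it near the level of compound 1. The estimate for compound 3 in this assay is 4000 nM, with a range from 1000 nM to 16000 nM.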

Compound 3, half-maximal inhibitory concentration: 5500 nM
For compound 3 the middle estimate is 1.4-fold (0.14 log units) below the measured one; measured number inside the range.
By their numbers in this assay, from the lowest: compound 1; then compound 3; then compound 2.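

In this assay, putting 4-(methanesulfonamido)butyl in place of amino on a saturated chain carbon bound to an amide-type nitrogen gives a 4.8-fold lower number from compound 2 to compound 3 (0.68 log units; beyond the scatter), so a large improvement at this terminus does not depend on a ring, as the entering group contains none. The 4-(2-hydroxyethyl)piperidin-1-yl group of compound 1 is therefore not the only terminus that improves on the (aminomethyl)amino end of compound 2, yet it keeps a modest lead, since (5-(methanesulfonamido)pentyl)amino in its place on the carbonyl carbon gives a 2.1-fold higher number from compound 1 to compound 3 (0.33 log units; beyond the scatter). No measurement shown here accounts for either step.

Because chain length and the methanesulfonamide end change together in compound 3, the compounds shown leave open which of the two carries the gain, a question that a plain pentyl chain or a hydroxyl at the end of the same chain would address. They also leave open how the number responds to a shorter or longer chain carrying the same methanesulfonamide, or to a carboxylic acid in its place.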